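Methoxyphenyl position change in a small series

The compounds below may be only part of what the source reports. "The series", "measured", "known", "first", "only" and "open" are said of these compounds alone.

Measured in a functional assay on MCF7 cells (Homo sapiens) for antiproliferative activity, read by MTT assay, with a stated time of 48 h; on this read-out higher numbers stand for weaker inhibition and lower numbers for stronger inhibition:
compound 1 `O=C(/C=C/c1ccc(O)c(O)c1)N1CCN(c2ccccc2Cl)CC1` gives 1.36 ug/mL
compound 2 `O=C(/C=C/c1ccc(O)c(O)c1)N1CCN(c2cccc(Cl)c2)CC1` gives 1.34 ug/mL
compound 3 `COc1ccccc1N1CCN(C(=O)/C=C/c2ccc(O)c(O)c2)CC1` gives 0.54 ug/mL

Compound 3 stands lowest of the three, with a 2.5-fold lower number from compound 1 to compound 3 (0.40 log units; beyond the scatter) and a 2.5-fold lower number from compound 2 to compound 3 (0.39 log units; beyond the scatter) as modest steps, both beyond the scatter. The next structure is compound 4 `COc1cccc(N2CCN(C(=O)/C=C/c3ccc(O)c(O)c3)CC2)c1`, which differs from compound 3 by 3-methoxyphenyl in place of 2-methoxyphenyl on an amine nitrogen in a ring and carries 3-methoxyphenyl in place of 2-methoxyphenyl on an amine nitrogen in a ring. For the measured compounds named here, the closest precedent is the same kind of change in the chlorophenyl pair, a 1.0-fold lower number from compound 1 to compound 2 (0.01 log units; within the scatter), which lies within the scatter. That step points to little change here. Going by the values given here, one caution remains: the lower number has been seen only with 2-methoxyphenyl, and no measured compound carries 3-methoxyphenyl. If the methoxy gain holds only for that group, compound 4 could move toward compound 2 at 1.34 ug/mL, so the range is wider on the upper side. The step expected in this assay is a 1.3-fold higher number from compound 3 to compound 4 (0.11 log units; within the scatter), slightly upward if anything and not expected to exceed the scatter. For compound 4 the estimated value is 0.7 ug/mL, with an expected range from 0.3 ug/mL to 1.6 ug/mL.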

Compound 4, half-maximal inhibitory concentration: 0.92 ug/mL
Beside the measured number, compound 4's estimate is 1.3-fold (0.12 log units) below it; low and high end bracket the measured number.
By their numbers in this assay, from the lowest: compounds 3, 4, 2 and 1 (each within the scatter of the next, the first and the last beyond it).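

In this assay, 3-methoxyphenyl in place of 2-methoxyphenyl gives a 1.7-fold higher number from compound 3 to compound 4 (0.23 log units; within the scatter), so the chlorophenyl pair's tolerance of this kind of change now has a second example, with methoxy as the substituent. Against the chloro compounds, 3-methoxyphenyl in place of 2-chlorophenyl gives a 1.5-fold lower number from compound 1 to compound 4 (0.17 log units; within the scatter) and methoxy in place of chloro gives a 1.5-fold lower number from compound 2 to compound 4 (0.16 log units; within the scatter), so the separation from the chloro compounds seen with 2-methoxyphenyl is not seen with 3-methoxyphenyl. The methoxy-for-chloro change therefore clears the scatter on only one of the two cores, yet the two steps cannot be told apart, and no dependence on where the group sits can be claimed: the same change on two cores in this assay, a 2.5-fold lower number (0.40 log units; beyond the scatter) from compound 1 to compound 3 and a 1.5-fold lower number (0.16 log units; within the scatter) from compound 2 to compound 4, 1.7-fold (0.24 log units) apart, within the scatter of two such steps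

These compounds leave open whether an amine, a hydroxy group or a longer ether such as ethoxy on the phenyl ring would keep the number near that of compound 3 or fall with the chloro compounds. An unsubstituted phenyl would be needed as a reference to show whether methoxy or chloro moves the number at all.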